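The source may hold more compounds than are shown below. What is called first, only, known or untested is meant among the compounds shown, and "the series" means these compounds.

Of the compounds shown here, two have so far been measured in a functional assay for inhibition, with Homo sapiens as the target; a higher number here means a weaker inhibitor, a lower number a stronger inhibitor. Compound 2 `COc1cccc(Nc2nccc(-c3ccncc3)n2)c1` gives 400 nM, the lowest of the two numbers. For the measured compounds named here, compound 1 `Cc1ccc(-c2ccnc(Nc3cccc(N(C)C)c3)n2)s1` gives 5700 nM, a number beyond the scatter above that of compound 2; these two differ in two places, so no single step links them. Compound 3 `COc1cccc(Nc2nccc(-c3ccc(C)s3)n2)c1` is unmeasured and differs from compound 2 in one place: 5-methylthiophen-2-yl in place of pyridin-4-yl on an aromatic carbon. Compound 1 also carries 5-methylthiophen-2-yl and gives 5700 nM. A step toward a weaker inhibitor is therefore expected, a 6.3-fold higher number from compound 2 to compound 3 (0.80 log units; beyond the scatter). Compound 3 is estimated to give 2500 nM, within 800 nM to 8000 nM.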

Compound 3, half-maximal inhibitory concentration: 2300 nM
The estimate for compound 3 lay 1.1-fold (0.04 log units) above the measured number, within the range that was stated.
By their numbers in this assay, from the lowest: compound 2; then compound 3; then compound 1.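

In this assay, putting 5-methylthiophen-2-yl in place of pyridin-4-yl gives a 5.8-fold higher number from compound 2 to compound 3 (0.76 log units; beyond the scatter), so with the methoxy compounds this position now shows a direct effect of the ring it carries, and pyridin-4-yl gives the stronger inhibitor of the pair. Compound 3 also connects compound 1 to this series through one change elsewhere, methoxy in place of dimethylamino, which gives a 2.5-fold lower number from compound 1 to compound 3 (0.39 log units; beyond the scatter) and shows that this second place also affects the number.

Going by these compounds, how a plain phenyl ring or a pyridin-3-yl ring would compare at this position remains open. Nothing available yet explains why either step occurs.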